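Capping the hydroxy group of compound 2

The source may report more compounds than this note shows. Statements on the series, on what has been measured and on what is new or still open speak of the compounds shown alone.

Of the compounds shown here, two have measured values so far. In a functional assay on MCF7 cells (Homo sapiens) for cytotoxicity, read by sulforhodamine B assay, with a stated time of 48 h (a lower number here means a stronger inhibitor, a higher number a weaker inhibitor), compound 1 `COc1cc(/C=C/C(=O)c2ccc(N)c(-c3ccc(F)cc3)c2)ccc1O` gives 10500 nM, and compound 2 `COc1cc(/C=C/C(=O)c2cccc(-c3cccc(F)c3)c2)ccc1O` gives 14200 nM. These two values lie within the scatter of each other, so compound 2 stands with compound 1 and no order can be read between them. Within the data shown here, the two compounds differ in more than one place, and no measured pair isolates a single change, so the series offers no step to serve as a precedent.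

Compound 3 `COc1ccc(/C=C/C(=O)c2cccc(-c3cccc(F)c3)c2)cc1OC` differs from compound 2 in one place: methyl in place of hydrogen on an oxygen on an aromatic ring. This is methyl in place of hydrogen on an oxygen on an aromatic ring, or hydroxy to methoxy. Among the measured compounds shown here, with no precedent for this change, the working anchor is compound 2 at 14200 nM, and no shift beyond the scatter is expected in this assay. A move in either direction cannot be excluded. The expected step is a 1.1-fold higher number from compound 2 to compound 3 (0.02 log units; within the scatter), an estimate that stays within the scatter. For compound 3 the estimated value is 15000 nM, with an expected range from 6000 nM to 38000 nM.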

Compound 3, half-maximal inhibitory concentration: 4620 nM
Compound 3: middle estimate off by 3.2-fold (0.51 log units), on the high side; the whole stated range lies above it.
By their numbers in this assay, from the lowest: compound 3; then compounds 1 and 2 (each within the scatter of the next).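

Hydroxy to methoxy is the first single change in the series that can be read, and in this assay it gives a 3.1-fold lower number from compound 2 to compound 3 (0.49 log units; beyond the scatter) on the oxygen on the aromatic ring. The step lies beyond the scatter, so the read-out responds to a change at this oxygen, and compound 3 shows that a free hydroxy group is not required there for cytotoxicity in these cells, although the step is modest and rests on a single pair. No information is available here on what lies behind the lower number of the capped compound.

From the compounds shown here alone, whether this result belongs to methyl itself or to capping of the oxygen more generally stays open, and a longer chain such as ethyl or an acetyl ester on the same oxygen would help to separate the two. Also open, going by these compounds, is whether the same change holds for the core of compound 1 at 10500 nM where the hydroxy group is still free.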